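The source may hold more compounds than are shown below. What is called first, only, known or untested is meant among the compounds shown, and "the series" means these compounds.

Working notes on the series. In a functional assay on MDA-N cells (Homo sapiens) for antiproliferative activity (a higher number here means a weaker inhibitor of growth, a lower number a stronger inhibitor of growth), compound 1 `Cc1cccc(-c2cc(O)c3ccc(C)nc3n2)c1` gives 31.6 nM and compound 2 `Oc1cc(-c2ccc3ccccc3c2)nc2ncccc12` gives 1660 nM. Compound 3 `Cc1cnc2[nH]c(-c3cccc(Cl)c3)cc(=O)c2c1` reads > 100000 nM in this assay, and this is a limit of the assay, not a number. Compound 4 `Cc1cnc2[nH]c(-c3cccc(F)c3)cc(=O)c2c1` is the next to be read. Its structure differs from that of compound 3 by fluoro in place of chloro on an aromatic carbon, which is fluoro in place of chloro on an aromatic carbon, meta to a large group. Among the compounds with values here, no measured pair isolates this exchange, so the expectation rests on the closest neighbour alone. That neighbour is compound 3, with its limit of > 100000 nM. A single-atom exchange of this kind is expected to leave compound 4 weak in this assay, and a second reading at the limit is quite possible. The expected change is an at least 3.3-fold lower number from compound 3 to compound 4 (0.52 log units; beyond the scatter), a modest move toward stronger growth inhibition or none visible. For compound 4 the estimate is 30000 nM, with an expected range from 2000 nM to 100000 nM.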

Compound 4, concentration for 50% growth inhibition: 11.8 nM
Estimate against measurement, compound 4: 2500-fold (3.41 log units) above; measured number below the stated range.
By their numbers in this assay, from the lowest: compound 4; then compound 1; then compound 2. At a limit, above all of these: compound 3.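

In this assay, fluoro in place of chloro on an aromatic carbon, meta to a large group, gives an at least 8400-fold lower number from compound 3 to compound 4 (3.92 log units; beyond the scatter), so a single heavy atom at this position separates a reading at the limit from a measured number. Compound 3 reads > 100000 nM, which is a limit of the assay and not a number. The step therefore has only a lower bound on its size, because compound 3 sits at that limit: the limit of > 100000 nM in this assay, at which 1 of the 4 values shown sits.

From the compounds shown here alone, it remains open whether the difference follows from the presence of fluoro or the absence of chloro, a question that hydrogen, methoxy or an amine on the same aromatic carbon would address. Also open, going by these compounds, is whether this exchange has a similar outcome on the cores of compound 1 and compound 2.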